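The compounds below may be only part of what the source reports. "The series", "measured", "known", "first", "only" and "open" are said of these compounds alone.

Measured so far:
compound 1 `S=C(Nc1ccc(Oc2ccccc2)cc1)Nc1ccc2[nH]ccc2c1` — "not active" (no number reported)
compound 2 `CCOC(=O)c1ccc(NC(=S)Nc2ccc3[nH]ccc3c2)cc1` — 71000 nM

Among the compounds with values here, in an ADME assay on cells for inhibition of Amine oxidase [flavin-containing] A (Homo sapiens), read by spectrophotometry (on this read-out lower numbers stand for stronger inhibition and higher numbers for weaker inhibition), compound 2 gives 71000 nM, a weak result and the only number available, since compound 1 is reported only as "not active" (no number reported). Compound 3 `CC(=O)Nc1ccc(NC(=S)Nc2ccc3[nH]ccc3c2)cc1` is the next analogue, with acetamido in place of ethoxycarbonyl on an aromatic carbon. Within the data shown here, no step between two measured compounds is known here, so nothing indicates how this kind of exchange shifts the read-out. Among the measured compounds shown here, with only one weak number to build on, the step from compound 2 to compound 3 in this assay is expected to be small, a 1.1-fold higher number from compound 2 to compound 3 (0.05 log units; within the scatter), in no clear direction beyond the scatter. Compound 3 is accordingly estimated at 80000 nM, within 20000 nM to 300000 nM.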

Compound 3, half-maximal inhibitory concentration: 71000 nM
For compound 3 the middle estimate is 1.1-fold (0.05 log units) above the measured one; the measured number falls inside the stated range.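

Within the data shown here, this is the first pair of compounds that differ in one place: in this assay, putting acetamido in place of ethoxycarbonyl gives no change at the digits printed from compound 2 to compound 3 (within the scatter). At this aromatic carbon, para to a large group, the exchange adds a hydrogen-bond donor and leaves the read-out where it was. No measured evidence here offers an explanation for this. Going by these compounds, whether a free amine or a carboxylic acid at this place would shift the number stays open, as does whether any group here can lift inhibition above this weak level.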